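The compounds below may be only part of what the source reports. "The series", "measured", "known", "first", "only" and "open" are said of these compounds alone.

Measured compounds in an assay on HEK293 cells for activation of Kir3.1/Kir3.2 (Homo sapiens), read by thallium flux; a higher number here means a larger maximal response, a lower number a smaller maximal response:
compound 1 `Cc1cc(NC(=O)Cn2nnc(-c3ccccc3)n2)n(C(C)C)n1`, compound 1 gives 107%
compound 2 `O=C(Cn1nnc(-c2ccccc2)n1)Nc1cc(C2CC2)nn1C1CCCCC1`, compound 2 gives 45%
compound 3 `Cc1cc(NC(=O)Cn2nnc(-c3cccc(F)c3)n2)n(C2CCCCC2)n1`, compound 3 gives 96%

Within this small set, compound 3 sits second highest of the three numbers in this assay. Its nearest neighbour is compound 1, whose number is higher by a margin beyond the usual scatter; the furthest is compound 2, whose number lies well below it, also beyond the scatter. Within the data shown here, no pair among the three differs in a single place, so no directly comparable step is at hand for the change now under consideration.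

Compound 4 `Cc1cc(NC(=O)Cn2nnc(-c3cccc(C#N)c3)n2)n(C2CCCCC2)n1` is the next compound for this assay. It differs from compound 3 as follows: cyano in place of fluoro on an aromatic carbon. Among the measured compounds shown here, no compound in the set shows the effect of a cyano or of this exchange, so the expectation rests only on the standing of compound 3 and the general observation that the three measured values fall in a broad range.

The step from compound 3 to compound 4 is expected to be a number 6 percentage points lower from compound 3 to compound 4 (within the scatter), within the scatter, because compound 3 already gives 96%. Compound 4 is thus estimated at 90%, with a range from 65% to 110%.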

Compound 4, largest response reached (Emax), in percent of the reference or control that the assay uses: 80%
Estimate against measurement, compound 4: 10 percentage points above, and the stated range covers the measured number.
By their numbers in this assay, from the lowest: compound 2; then compound 4; then compound 3; then compound 1.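

In this assay, among these compounds, the exchange of 3-fluorophenyl for 3-cyanophenyl provides the only single-place comparison: a number 16 percentage points lower from compound 3 to compound 4 (beyond the scatter). This aromatic carbon is therefore sensitive to the group it carries, although compound 4 still gives 80% with cyano there. Nothing measured here accounts for the drop.

Open, going by these compounds, is whether an amine, a carboxylic acid or a methoxy group on this aromatic carbon would hold the response or lower it further. On these data alone, compound 1 and compound 2 carry neither fluoro nor cyano, and whether the same exchange would give a step of similar size on their scaffolds also remains open.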